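The source may report more compounds than this note shows. Statements on the series, on what has been measured and on what is new or still open speak of the compounds shown alone.

Of the compounds shown here, three sharing one core have been tested in a functional assay on SN12C cells (Homo sapiens) for inhibition, read by sulforhodamine B assay, with a stated time of 48 h, tested at 100 uM; a higher number here means a weaker effect of the compound at the concentration tested, a lower number a stronger effect. Compound 3 `COc1cc(Cl)cc(-c2nn(-c3cccc(NC(=O)Nc4ccc(Cl)c(Cl)c4)c3)cc2-c2ccncc2)c1` gives 5%, the highest of the three numbers and thus the weakest effect at the concentration tested. Compound 1 `COc1cc(Cl)cc(-c2nn(-c3cccc(NC(=O)Nc4ccc(Cl)c(C(F)(F)F)c4)c3)cc2-c2ccncc2)c1` gives -43%, and compound 2 `COc1cc(Cl)cc(-c2nn(-c3cccc(NC(=O)Nc4cc(C(F)(F)F)cc(C(F)(F)F)c4)c3)cc2-c2ccncc2)c1` gives -61%; the step from each of them up to compound 3 lies beyond the scatter.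

The next compound, compound 4 `COc1cc(Cl)cc(-c2nn(-c3cccc(NC(=O)Nc4cccc(C(F)(F)F)c4)c3)cc2-c2ccncc2)c1`, has not yet been measured. It differs from compound 3 in one place: 3-(trifluoromethyl)phenyl in place of 3,4-dichlorophenyl on an amide-type nitrogen. On that amide-type nitrogen, two chlorines therefore leave and one trifluoromethyl group enters.

Among the measured compounds shown here, one measured step bears on this. a number 48 percentage points higher from compound 1 to compound 3 (beyond the scatter), a marked weakening when trifluoromethyl gave way to chloro. Compound 4 carries a trifluoromethyl group again, but it also lacks the chloro that compound 1 retains, so the reversal may be only partial. For the measured compounds named here, compound 2 shows the lowest number of the three, but no single-point step connects it to compound 4.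

The step to compound 4 is therefore expected to be a number 30 percentage points lower from compound 3 to compound 4 (beyond the scatter), downward and beyond the scatter. For compound 4 the estimated value in this assay is -25%, with a range from -60% to 10%.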

Compound 4, a percentage reported as activity, at one concentration (the size of the read-out at that concentration, not a potency): -20%
Compound 4: middle estimate off by 5 percentage points, on the low side; the range from low to high includes it.
By their numbers in this assay, from the lowest: compound 2; then compound 1; then compound 4; then compound 3.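

The change to a 3-(trifluoromethyl)phenyl group on the amide-type nitrogen shows that a single trifluoromethyl group, with no second group on that ring, is enough to move the read-out in this assay down, with a number 25 percentage points lower from compound 3 to compound 4 (beyond the scatter) as the step, so the weak effect of compound 3 does not reflect a need for more ring substituents. Among the compounds shown here, compound 4 also serves as the reference that the earlier compounds lacked: a number 41 percentage points higher from compound 2 to compound 4 (beyond the scatter) on removal of the second trifluoromethyl group, and a number 23 percentage points higher from compound 1 to compound 4 (beyond the scatter) on removal of the chloro, so in both pairs a second group on this ring goes with the lower number. No measurement at hand explains any of these shifts.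

These compounds leave open how this ring would behave with a nitrile, a dimethylamino group or a carboxylic acid in place of trifluoromethyl, or with no group on it at all. From the compounds shown here alone, whether the same order would hold at lower concentrations, or in other cell lines, also remains open, since every number here comes from a single concentration in one cell line.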